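Benzyloxy variation on a shared diaryloxy amine core

This account rests on a few compounds, and the source may have more. Where it says the series, first, only, none or still open, it means among the compounds named here.

Measured compounds in a functional assay on PC-3 cells (Homo sapiens) for cytotoxicity, read by sulforhodamine B assay; on this read-out higher numbers stand for weaker inhibition of growth and lower numbers for stronger inhibition of growth:
compound 1, `COc1cccc(OC)c1OCCNCCOc1ccccc1OCc1cccc(Cl)c1`, gives 20400 nM
compound 2, `COc1cccc(OC)c1OCCNCCOc1ccccc1OCc1ccc(Cl)cc1`, gives 14500 nM
compound 3, `COc1cccc(OC)c1OCCNCCOc1ccccc1OCc1ccc(C)cc1`, gives 27500 nM

All three numbers sit close together. Compound 3 has the largest of the three, but its steps to the others are small: a 1.3-fold higher number from compound 1 to compound 3 (0.13 log units; within the scatter) and a 1.9-fold higher number from compound 2 to compound 3 (0.28 log units; within the scatter), both within the scatter, as is a 1.4-fold lower number from compound 1 to compound 2 (0.15 log units; within the scatter). On the numbers shown, the substituent on the benzyl ring has not moved the read-out of this assay beyond repeat variation.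

Compound 4, `COc1ccccc1COc1ccccc1OCCNCCOc1c(OC)cccc1OC`, is not yet measured. It differs from compound 3 as follows: 2-methoxyphenyl in place of 4-methylphenyl on a saturated chain carbon bound to an oxygen on an aromatic ring. Among the measured compounds shown here, the steps that bear on this change are those that also alter the same benzyl ring, from compound 1 to compound 3 and from compound 2 to compound 3; both were within the scatter. Nothing in the series shows a benzyl-ring change that produced a step beyond the scatter, so no directional step is expected here either, and the estimate for the step from compound 3 to compound 4 is a 1.3-fold lower number from compound 3 to compound 4 (0.10 log units; within the scatter).

Compound 4 is therefore expected to give about 22000 nM in this assay, with a range from 9000 nM to 55000 nM.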

Compound 4, concentration for total growth inhibition: 30200 nM
Estimate against measurement, compound 4: 1.4-fold (0.14 log units) below; the measured number falls inside the stated range.
By their numbers in this assay, from the lowest: compounds 2, 1, 3 and 4 (each within the scatter of the next, the first and the last beyond it).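

In this assay, among the compounds shown here, replacing the benzyl-ring substituents with 2-methoxyphenyl on a saturated chain carbon bound to an oxygen on an aromatic ring gives the only step printed as beyond the scatter: a 2.1-fold higher number from compound 2 to compound 4 (0.32 log units; beyond the scatter) is a modest separation, and it holds only against the 4-chlorophenyl of compound 2. The same group does not separate compound 4 from the other two compounds, as a 1.1-fold higher number from compound 3 to compound 4 (0.04 log units; within the scatter) and a 1.5-fold higher number from compound 1 to compound 4 (0.17 log units; within the scatter) both remain within the scatter, so the oxygen-bearing substituent adds one hydrogen-bond acceptor to the count without setting compound 4 apart from the series as a whole. For the compounds shown here, nothing available here accounts for the single step beyond the scatter.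

The compounds shown leave open whether that step follows from the methoxy group itself or from where it sits on the ring, a question that 4-methoxyphenyl could address alongside the 2-methoxyphenyl of compound 4. They also leave open whether a benzyl ring carrying an amine or a carboxylic acid, or a longer chain in place of the benzyl link, would move the read-out further than any group seen so far.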